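A few compounds are considered here, and "the series" means these few. Any claim that something is new, unique, unknown or untested is made for them only; others in the source may bear on it.

Compound 1 `C=C(Br)C(=O)Nc1ccc(C(=O)/C=C/c2cccc(OC)c2OC)cc1`: 710 nM
Compound 2 `C=C(Br)C(=O)Nc1ccc(C(=O)/C=C/c2ccc(OC)c(OC)c2OC)cc1`: 840 nM

In an ADME assay on CCRF-CEM cells (Homo sapiens) for antiproliferative activity, with a stated time of 48 h (a lower number here means a stronger inhibitor, a higher number a weaker inhibitor), compound 1 gives 710 nM, and compound 2 gives 840 nM; the two numbers lie within the scatter of each other, as the step of a 1.2-fold higher number from compound 1 to compound 2 (0.07 log units; within the scatter) shows. Compound 3 `COc1cccc(/C=C/C(=O)c2ccc(N)cc2)c1OC` is the one still to be measured. Its change from compound 1 reads (hydrogen in place of (1-bromoethenyl)carbonyl on a nitrogen on an aromatic ring). Among the compounds with values here, the only measured step concerns a methoxy group on the ring and does not bear on this change, so no measured step guides the expectation. Compound 3 is estimated to show a higher number, 6000 nM, with a wide range from 1200 nM to 30000 nM, an expected step of an 8.5-fold higher number from compound 1 to compound 3 (0.93 log units; beyond the scatter).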

Compound 3, half-maximal inhibitory concentration: 7600 nM
The estimate for compound 3 lay 1.3-fold (0.10 log units) below the measured number, and the stated range covers the measured number.
By their numbers in this assay, from the lowest: compounds 1 and 2 (each within the scatter of the next); then compound 3.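

In this assay, replacing the (1-bromoethenyl)carbonyl on the nitrogen with hydrogen gives an 11-fold higher number from compound 1 to compound 3 (1.03 log units; beyond the scatter), so this position, unlike the methoxy position on the other ring, carries a large change in the number. The whole group leaves at once, so the step speaks for the group as a unit and not for any one of its parts. Nothing measured here gives a reason for this step.

The compounds shown leave open whether the bromine, the double bond or the carbonyl accounts for the step. An acetyl group or a (1-chloroethenyl)carbonyl on that nitrogen would bear on this.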